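Alkynyl-Uracil Antiproliferatives: From Octyl to Pentylphenyl

The source may hold more compounds than are shown below. What is called first, only, known or untested is meant among the compounds shown, and "the series" means these compounds.

Three compounds share a core in which a uracil ring carries an alkyne and a phthalimide-capped linker, differing only in the group on the outer triple-bonded carbon. Compound 1 `CCCCCCCCC#Cc1cn(C/C=C\CN2C(=O)c3ccccc3C2=O)c(=O)[nH]c1=O` carries an octyl chain there and in a functional assay on MCF7 cells (Homo sapiens) for antiproliferative activity, read by MTT assay, with a stated time of 3 days (a higher number here means a weaker inhibitor, a lower number a stronger inhibitor), compound 1 gives 64000 nM, the highest of the two numbers reported. Compound 3 `CCCCc1ccc(C#Cc2cn(C/C=C\CN3C(=O)c4ccccc4C3=O)c(=O)[nH]c2=O)cc1` carries a 4-butylphenyl group and in this assay compound 3 gives 43000 nM, so that a 1.5-fold lower number from compound 1 to compound 3 (0.17 log units; within the scatter). Compound 2 `O=C1c2ccccc2C(=O)N1C/C=C\Cn1cc(C#Cc2ccc(Br)cc2)c(=O)[nH]c1=O` carries a 4-bromophenyl group, and for compound 2 this assay reports only a limit, > 100000 nM. Comparing the two aryl compounds, an at least 2.3-fold lower number from compound 2 to compound 3 (0.36 log units; beyond the scatter), and an at least 1.5-fold higher number from compound 1 to compound 2 (0.19 log units; that floor lies within the scatter), where the limit of > 100000 nM in this assay, at which 1 of the 3 values shown sits, marks that the value for compound 2 is a limit rather than a number.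

Compound 4 `CCCCCc1ccc(C#Cc2cn(C/C=C\CN3C(=O)c4ccccc4C3=O)c(=O)[nH]c2=O)cc1` is not yet measured. It differs from compound 1 by 4-pentylphenyl in place of octyl on a triple-bonded carbon. For the measured compounds named here, the closest measured step is the one from compound 1 to compound 3, which was within the scatter, and the move from bromo to butyl on the aromatic carbon favoured the alkyl-bearing aryl. A pentyl chain on the phenyl is one carbon longer than butyl, so compound 4 is expected to behave much like compound 3, with a 1.6-fold lower number from compound 1 to compound 4 (0.20 log units; within the scatter). Compound 4 is therefore estimated at 40000 nM, within a range from 18000 nM to 90000 nM.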

Compound 4, half-maximal inhibitory concentration: > 100000 nM
Compound 4: only a limit was reported; the forecaster's own chance of this, stated with the estimate: 15%; middle value at least 2.5-fold (0.39 log units) from the limit.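

Within the aryl pair, lengthening the chain on the phenyl ring by one carbon is not a neutral change: adding a methyl to the end of the butyl chain gives an at least 2.3-fold higher number from compound 3 to compound 4 (0.36 log units; beyond the scatter) in this assay, so a small edit far out on the group can separate a measurable compound from an unmeasurable one. Replacing octyl with 4-pentylphenyl on the triple-bonded carbon gives an at least 1.5-fold higher number from compound 1 to compound 4 (0.19 log units; that floor lies within the scatter), so this comparison cannot show that compound 4 differs from compound 1, even though compound 3, the 4-butylphenyl analogue, showed no difference from compound 1 beyond the scatter either. The value for compound 4 is only a limit, as is the value for compound 2, so the step between those two cannot be read, and both compounds now sit at the same ceiling: the limit of > 100000 nM in this assay, at which 2 of the 4 values shown sit.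

From the compounds shown here alone, it remains open whether a shorter propyl chain or a longer hexyl chain on the phenyl ring would give a readable number. Also unresolved is how an amine or a carboxylic acid at the end of that chain would compare with compound 3.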